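Aryl swap on the sulfoxide of the anilide series

This account rests on a few compounds, and the source may have more. Where it says the series, first, only, none or still open, it means among the compounds named here.

Among the measured compounds shown here, compound 1 `CC(O)(C[S+]([O-])c1ccc(F)cc1F)C(=O)Nc1ccc([N+](=O)[O-])cc1C(F)(F)F` is, in a functional assay on CWR22R cells (Homo sapiens) for antiproliferative activity (a higher number here means a weaker inhibitor, a lower number a stronger inhibitor), the only member with a single number: compound 1 gives 51100 nM, while one further run of it returned no number. Compound 2 `CC(O)(C[S+]([O-])c1ccc(C(F)(F)F)cn1)C(=O)Nc1ccc(C#N)c(C(F)(F)F)c1` differs from compound 1 in more than one place and has been run repeatedly, (the several entries of compound 2 in this assay, 65500 nM; 77000 nM (2 entries)); in this assay compound 2 gives 65500 nM; 77000 nM (2 entries), which sits within the usual scatter of the value for compound 1. For the measured compounds named here, both measured compounds are therefore weak, and no single-point step between them is known.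

Compound 3 `CC(O)(C[S+]([O-])c1ccc(C(F)(F)F)cc1)C(=O)Nc1ccc([N+](=O)[O-])cc1C(F)(F)F` is not yet measured. It differs from compound 1 by 4-(trifluoromethyl)phenyl in place of 2,4-difluorophenyl on a sulfur. Going by the values given here, with no measured step of this kind to lean on, and both known values lying close together, the step from compound 1 to compound 3 is expected to stay within the scatter, a 1.1-fold lower number from compound 1 to compound 3 (0.03 log units; within the scatter). For compound 3 the estimate in this assay is 48000 nM, with a range of 20000 nM to 110000 nM.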

Compound 3, half-maximal inhibitory concentration: 21100 nM
For compound 3 the middle estimate is 2.3-fold (0.36 log units) above the measured one; low and high end bracket the measured number.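

Among the compounds shown here, the aryl group on the sulfur of the sulfoxide is the first place where a single change can be read: in this assay, 4-(trifluoromethyl)phenyl in place of 2,4-difluorophenyl gives a 2.4-fold lower number from compound 1 to compound 3 (0.38 log units; beyond the scatter). The position therefore responds to the choice of aryl group, although the step is modest and compound 3 still gives 21100 nM. Repeat entries in the series stay close together, so the step is unlikely to be run-to-run noise alone: the several entries of compound 2 in this assay, 65500 nM; 77000 nM (2 entries)

The step exchanges one whole aryl group for another, so it does not show which part of the change carries the effect. Also open, as far as these compounds go, are whether a non-aromatic group on the sulfur, such as cyclohexyl or a chain ending in an amine, would be tolerated, and whether the same step holds with the nitrile-bearing anilide of compound 2.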